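Neopentyl Replacing Isopropyl at the Ring Amine Nitrogen

The source may hold more compounds than are shown below. What is called first, only, known or untested is meant among the compounds shown, and "the series" means these compounds.

Of the compounds shown here, two have been measured so far. Compound 1 `CN1CCCN(CCn2ccc3ccc(-c4ccsc4)cc32)CC1` in an assay on HEK293 cells for binding affinity to 5-hydroxytryptamine receptor 7 (Homo sapiens), read by radioligand binding, tested at 1 uM (on this read-out higher numbers stand for more inhibition at the one concentration tested (going by the name of the read-out) and lower numbers for less inhibition), gives 68%. Compound 2 `CC(C)N1CCCN(CCn2ccc3ccc(Br)cc32)CC1` in this assay gives 92%. On these two numbers compound 2 stands highest; its nearest neighbour, compound 1, lies below it by a distance that exceeds the usual scatter of repeated measurements. Compound 3 `CC(C)(C)CN1CCCN(CCn2ccc3ccc(Br)cc32)CC1` has not yet been measured. It differs from compound 2 in one place: neopentyl in place of isopropyl on an amine nitrogen in a ring. No change of this kind links two measured compounds, so its effect cannot be read off from the data. With a neopentyl in place of isopropyl on the same ring nitrogen, the step expected from compound 2 to compound 3 in this assay is a number 8 percentage points lower from compound 2 to compound 3 (within the scatter), a modest decrease that may stay within the scatter. Compound 3 is therefore expected to give 84%, within a range from 62% to 98%.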

Compound 3, a percentage reported as inhibition, at one concentration (the size of the read-out at that concentration, not a potency): 70%
For compound 3 the middle estimate is 14 percentage points above the measured one; measured number inside the range.
By their numbers in this assay, from the lowest: compounds 1 and 3 (each within the scatter of the next); then compound 2.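

Among the compounds shown here, this is the first measured change at this ring nitrogen. In this assay, neopentyl in place of isopropyl gives a number 22 percentage points lower from compound 2 to compound 3 (beyond the scatter), so the read-out is sensitive to which of these two carbon groups sits on the nitrogen. The rest of the two structures is identical, which ties the step to this single swap, but the data offer no measurement that explains the drop.

As far as these compounds go, two groups at one position give a single step and do not make a trend, so it remains open whether other groups would follow it. An ethyl, a cyclopropyl or a longer chain such as n-butyl on the same nitrogen could show how the read-out responds across a wider set of groups, and whether neopentyl is a special case.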